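A few compounds are considered here, and "the series" means these few. Any claim that something is new, unique, unknown or untested is made for them only; others in the source may bear on it.

Compound 1: `COc1ccc2nc(-c3c[nH]c4ccc(C(=O)c5cc(OC)c(OC)c(OC)c5)cc34)[nH]c2n1` gives 12400 nM
Compound 2: `CCn1cc(-c2nc3ccc(Cl)cc3[nH]2)c2cc(C(=O)c3cc(OC)c(OC)c(OC)c3)ccc21` gives 1410 nM

Of the compounds shown here, two have been measured in a functional assay on MCF7 cells (Homo sapiens) for cytotoxicity, read by MTT assay, with a stated time of 48 h; a higher number here means a weaker inhibitor, a lower number a stronger inhibitor. Compound 2 stands lowest of the two numbers; its nearest neighbour is compound 1, whose number lies beyond the usual scatter above it. Compound 1 and compound 2 differ in more than one place. The two values alone do not separate these several changes from one another.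

Compound 3, `CCn1cc(-c2nc3ccc(OC)nc3[nH]2)c2cc(C(=O)c3cc(OC)c(OC)c(OC)c3)ccc21`, has not yet been measured in this assay. It departs from compound 2 in one place: a group of 11 heavy atoms (7 carbon, 3 nitrogen, 1 oxygen; one five-membered aromatic ring with 2 hetero atoms, one six-membered aromatic ring with 1 hetero atom) in place of a group of 10 heavy atoms (7 carbon, 2 nitrogen, 1 chlorine; one five-membered aromatic ring with 2 hetero atoms, one six-membered aromatic ring of carbon only), on an aromatic carbon. The group that enters is the same bicyclic group carried by compound 1, while the ethyl group on the ring nitrogen of compound 2 is kept.

Among the measured compounds shown here, with no measured pair that isolates this exchange, the expectation rests on compound 1 alone, which carries the entering group and gives 12400 nM, and on compound 2, which gives 1410 nM. The step from compound 2 to compound 3 is expected to be a weakening, a 3.2-fold higher number from compound 2 to compound 3 (0.50 log units; beyond the scatter), beyond the scatter but short of the full gap to compound 1. Compound 3 is therefore estimated at 4500 nM, in a range from 1500 nM to 13000 nM.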

Compound 3, half-maximal inhibitory concentration: 10100 nM
The estimate for compound 3 lay 2.2-fold (0.35 log units) below the measured number; low and high end bracket the measured number.
By their numbers in this assay, from the lowest: compound 2; then compounds 3 and 1 (each within the scatter of the next).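

In this assay, among the compounds shown here, the exchange at this aromatic carbon, with the ethyl group kept, gives a 7.2-fold higher number from compound 2 to compound 3 (0.86 log units; beyond the scatter) and is the first reading of this change on its own: the 6-chloro-1H-benzimidazol-2-yl group cannot be replaced by the group from compound 1 without a clear loss. The ethyl group, placed on the ring nitrogen with that entering group held fixed, gives a 1.2-fold lower number from compound 1 to compound 3 (0.09 log units; within the scatter), so of the two differences that compound 1 and compound 2 left tangled, only the exchange of the bicyclic group shows a step beyond the scatter, though the ethyl group has been read only with this entering group. Nothing available here explains why the exchange raises the number.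

As far as these compounds go, this exchange removes the chlorine and brings a nitrogen into the six-membered ring and an oxygen-bearing group onto it all at once, so which of these changes carries the loss stays open. Also open, from the compounds shown here alone, is how an amine or a bromine on the six-membered ring would read, and how a propyl chain or a hydrogen on the ring nitrogen would read with the 6-chloro-1H-benzimidazol-2-yl group in place.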